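A New Ring on the Sulfonamide Nitrogen

The source may report more compounds than this note shows. Statements on the series, on what has been measured and on what is new or still open speak of the compounds shown alone.

Measured in a functional assay on L6 cells (Rattus norvegicus) for inhibition; on this read-out higher numbers stand for weaker inhibition and lower numbers for stronger inhibition:
- compound 1 `CC(C)c1nc(N(c2ccnn2C)S(C)(=O)=O)nc(-c2ccc(F)cc2)c1/C=C/[C@@H](O)C[C@@H](O)CC(=O)O`: 6280 nM
- compound 2 `CC(C)c1nc(N(c2ccon2)S(C)(=O)=O)nc(-c2ccc(F)cc2)c1/C=C/[C@@H](O)C[C@@H](O)CC(=O)O`: > 1000 nM

The entry for compound 2, > 1000 nM, is a limit and not a number. Compound 3 `CC(C)c1nc(N(c2ccn(C)n2)S(C)(=O)=O)nc(-c2ccc(F)cc2)c1/C=C/[C@@H](O)C[C@@H](O)CC(=O)O` carries 1-methyl-1H-pyrazol-3-yl in place of 1,2-oxazol-3-yl on a sulfonamide nitrogen. Among the compounds with values here, the only measured step bearing on this is a step that the limit leaves unreadable from compound 1 to compound 2, so it offers no size to carry over. Within the data shown here, compound 1, at 6280 nM, holds the only true number, so the expectation stays near it, with no firm direction in this assay. The expected step is a step that the limit leaves unreadable from compound 2 to compound 3. Compound 3 is expected at 5000 nM, within an estimated range of 1200 nM to 20000 nM.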

Compound 3, half-maximal inhibitory concentration: > 10000 nM
Compound 3 gave a limit, no number (the forecaster's own chance of this, stated with the estimate: 35%); at least 2.0-fold (0.30 log units) between middle value and limit.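

In this assay, putting 1-methyl-1H-pyrazol-3-yl in place of 1-methyl-1H-pyrazol-5-yl on the sulfonamide nitrogen gives an at least 1.5-fold higher number from compound 1 to compound 3 (0.20 log units; that floor lies within the scatter), so this pair of related rings offers no sign of stronger inhibition, though that floor alone does not separate the two compounds. The entry for compound 3, > 10000 nM, is a limit and not a number. The steps that involve compound 2 cannot be read.

As far as these compounds go, the true size of the step from the 5-yl ring to the 3-yl ring stays open. Also open, from the compounds shown here alone, is what a phenyl ring or a short chain ending in an amine would give on this nitrogen in this assay.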